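The source may report more compounds than this note shows. Statements on the series, on what has been measured and on what is new or still open speak of the compounds shown alone.

Working notes on the series, sigma intracellular receptor 2 binding.

Three compounds on the shared core have been run in an assay on membranes from liver for displacement of a labelled ligand from Sigma intracellular receptor 2 (Rattus norvegicus), read by scintillation counting, with a stated time of 120 min, in the presence of a further agent that is not named here; a lower number here means a stronger inhibitor, a higher number a weaker inhibitor. Compound 1 `c1ccc(CCCNC2CCc3ccsc3CC2)cc1` gives 5.1 nM. Compound 2 `c1ccc(CCCCNC2CCc3ccsc3CC2)cc1` gives 5.7 nM, the second highest of the three numbers and within the scatter of compound 1, which sits nearest to it. Within the data shown here, compound 3 `CN(Cc1ccccc1)C1CCc2ccsc2CC1` gives 91 nM; compared with compound 2 this is a higher number beyond the scatter, but compound 3 differs from compound 2 in more than one place, so no single step separates the two.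

The next compound is compound 4 `CN(CCCCc1ccccc1)C1CCc2ccsc2CC1`. It differs from compound 2 by methyl in place of hydrogen on an amine nitrogen. Among the measured compounds shown here, the only single step measured so far, a 1.1-fold higher number from compound 1 to compound 2 (0.05 log units; within the scatter), concerns the chain and not the amine nitrogen, so it gives no direct guide to this change. The higher number of compound 3, which also carries a methyl on the amine nitrogen, is the nearest hint, though the shorter chain of compound 3 clouds it.

On this basis compound 4 is expected to give a higher number in this assay, estimated at 20 nM with a range of 5 nM to 80 nM, the expected step being a 3.5-fold higher number from compound 2 to compound 4 (0.55 log units; beyond the scatter).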

Compound 4, inhibition constant: 12 nM
Beside the measured number, compound 4's estimate is 1.7-fold (0.22 log units) above it; the measured number falls inside the stated range.
By their numbers in this assay, from the lowest: compounds 1 and 2 (each within the scatter of the next); then compound 4; then compound 3.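

Among these compounds, this is the first single step read at the amine nitrogen whose other neighbours are a saturated chain carbon and a saturated ring carbon: in this assay, methyl in place of hydrogen gives a 2.1-fold higher number from compound 2 to compound 4 (0.32 log units; beyond the scatter). The step is modest, so the hydrogen at this position can be replaced by methyl with only a small loss, and compound 4 still gives 12 nM. No measurement bears on why the step has this size.

The compounds shown leave open whether the same methyl step would hold on the chain of compound 1, since that pair is not among the compounds shown here. They also leave open how the series responds to a larger group on this amine nitrogen, such as an ethyl or a propyl, and so whether the modest step seen with methyl continues or grows as the group gets larger.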